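The source may hold more compounds than are shown below. What is called first, only, known or untested is meant among the compounds shown, and "the series" means these compounds.

Measured compounds:
- compound 1 `O=C(CN1CCC(Cc2ccccc2)CC1)Nc1ccc(C(=O)/C=C/c2cn(Cc3ccc(Br)cc3)nn2)cc1`: 41900 nM
- compound 2 `COc1ccccc1N1CCN(CC(=O)Nc2ccc(C(=O)/C=C/c3cn(Cc4ccc(Br)cc4)nn3)cc2)CC1`: 26400 nM

Of the compounds shown here, two sharing one core have been measured in a functional assay on HeLa cells (Homo sapiens) for inhibition, read by MTT assay; on this read-out higher numbers stand for weaker inhibition and lower numbers for stronger inhibition. Compound 1 gives 41900 nM. Compound 2 gives 26400 nM. The two numbers stand close to one another; their gap lies within the usual scatter of repeated measurements, so no order between compound 1 and compound 2 can be read from them.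

The next compound, compound 3 `O=C(CN1CCN(c2ccc([N+](=O)[O-])cc2)CC1)Nc1ccc(C(=O)/C=C/c2cn(Cc3ccc(Br)cc3)nn2)cc1`, is derived from compound 2 by a single change: 4-nitrophenyl in place of 2-methoxyphenyl on an amine nitrogen in a ring. The rest of the structure is unchanged.

Within the data shown here, no measured pair shows what such a change does at this position, and the two measured compounds themselves, which differ at the same amine nitrogen, sit within the scatter of each other. On that basis a step of any size beyond the scatter is not expected in this assay from compound 2 to compound 3; the expected step is a 1.1-fold higher number from compound 2 to compound 3 (0.06 log units; within the scatter). Compound 3 is therefore estimated at 30000 nM, with a likely range from 10000 nM to 90000 nM.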

Compound 3, half-maximal inhibitory concentration: 26600 nM
For compound 3 the middle estimate is 1.1-fold (0.05 log units) above the measured one, within the range that was stated.
By their numbers in this assay, from the lowest: compounds 2, 3 and 1 (each within the scatter of the next).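

In this assay, 4-nitrophenyl in place of 2-methoxyphenyl on the amine nitrogen in the ring gives a 1.0-fold higher number from compound 2 to compound 3 (0.00 log units; within the scatter) and so provides the first step read at this position from a single change. That step exchanges two things at once, the group carried by the aromatic ring and its place on that ring, yet the two compounds stay within the scatter of each other, so this one pair shows that these two aryl groups cannot be told apart in this read-out, though it gives no general rule for the position. Nothing available bears on why the two groups read alike.

The compounds shown leave open whether the group and its place on the aromatic ring would each matter when taken alone, a question that 4-methoxyphenyl or 2-nitrophenyl on the same nitrogen would address. They also leave open whether an unsubstituted phenyl, or a phenyl carrying an amine or a carboxylic acid, would stay within the scatter of compound 2 or move beyond it.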